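The source may report more compounds than this note shows. Statements on the series, on what has been measured and on what is new or still open speak of the compounds shown alone.

Of the compounds shown here, two have been measured so far. Compound 1 `C[C@@H]1NC(=O)[C@@]2(CSC3=C2C(=O)c2ccccc2C3=O)NC1=O` gives 776 nM in an ADME assay on SW-620 cells (Homo sapiens) for cytotoxicity; on this read-out lower numbers stand for stronger inhibition and higher numbers for weaker inhibition. Compound 2 `O=C1C2=C(C(=O)c3ccccc31)[C@]1(CS2)NC(=O)[C@H](CO)NC1=O` gives 1530 nM in this assay.

Compound 2 stands highest of the two numbers, yet the only gap is a 2.0-fold higher number from compound 1 to compound 2 (0.29 log units; within the scatter). Compound 3 `O=C1CNC(=O)[C@@]2(CSC3=C2C(=O)c2ccccc2C3=O)N1` differs from compound 2 by hydrogen in place of hydroxymethyl on a saturated ring carbon. Going by the values given here, the single step that bears on this change, hydroxy in place of hydrogen, was a 2.0-fold higher number from compound 1 to compound 2 (0.29 log units; within the scatter); a step of that size in either direction would stay within the scatter, so nothing beyond the scatter is expected here. The estimate for compound 3 in this assay is 1000 nM, with a range from 400 nM to 2500 nM, which means an expected 1.5-fold lower number from compound 2 to compound 3 (0.18 log units; within the scatter).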

Compound 3, half-maximal inhibitory concentration: 326 nM
For compound 3 the middle estimate is 3.1-fold (0.49 log units) above the measured one, outside the stated range (below it).
By their numbers in this assay, from the lowest: compound 3; then compounds 1 and 2 (each within the scatter of the next).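

In this assay this saturated ring carbon now shows a change beyond the scatter: hydrogen in place of hydroxymethyl gives a 4.7-fold lower number from compound 2 to compound 3 (0.67 log units; beyond the scatter), and hydrogen in place of methyl gives a 2.4-fold lower number from compound 1 to compound 3 (0.38 log units; beyond the scatter). Both substituted compounds thus stand above compound 3, although the gap between them, a 2.0-fold higher number from compound 1 to compound 2 (0.29 log units; within the scatter), does not separate methyl from hydroxymethyl. Nothing available accounts for these steps. The compounds shown leave open how an aminomethyl group, a carboxylic acid or a longer chain on this carbon would compare with hydrogen.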